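This account rests on a few compounds, and the source may have more. Where it says the series, first, only, none or still open, it means among the compounds named here.

Measured in a functional assay on MCF7 cells (Homo sapiens) for inhibition, read by sulforhodamine B assay, with a stated time of 48 h; on this read-out higher numbers stand for weaker inhibition of growth and lower numbers for stronger inhibition of growth:
compound 1, `COC(=O)c1sc2cc(Nc3ccccc3Br)cnc2c1N` — 28900 nM
compound 2, `COC(=O)c1sc2cc(Nc3cccnc3)cnc2c1N` — 82400 nM

Compound 2 holds the highest of the two numbers in this assay. Its nearest neighbour is compound 1, and the step between them, a 2.9-fold higher number from compound 1 to compound 2 (0.46 log units; beyond the scatter), runs in the direction of weaker growth inhibition. That step exchanges 2-bromophenyl for pyridin-3-yl on a nitrogen on an aromatic ring.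

Compound 3, `COC(=O)c1sc2cc(Nc3ncccn3)cnc2c1N`, is not yet measured. It differs from compound 2 by pyrimidin-2-yl in place of pyridin-3-yl on a nitrogen on an aromatic ring. Within the data shown here, no measured step covers this exchange: the only step available, from compound 1 to compound 2, replaces a carbocyclic ring with a heteroaromatic one, whereas here one heteroaromatic ring is replaced by another of the same size. There is no footing for predicting a shift in either direction beyond the scatter, so the expectation is that compound 3 stays close to compound 2, with a 1.1-fold higher number from compound 2 to compound 3 (0.04 log units; within the scatter) as the estimated step. Compound 3 is thus expected to give 90000 nM in this assay, within the range 30000 nM to 270000 nM, pending the measurement.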

Compound 3, concentration for 50% growth inhibition: > 150000 nM
Compound 3: only a limit was reported (the forecaster's own chance of this, stated with the estimate: 20%); at least 1.6-fold (0.22 log units) between middle value and limit.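

In this assay, compound 3 is reported only as a limit, not as a number: the limit of > 150000 nM in this assay, at which 1 of the 3 values shown sits.

The exchange of pyridin-3-yl for pyrimidin-2-yl on a nitrogen on an aromatic ring reads as an at least 1.8-fold higher number from compound 2 to compound 3 (0.26 log units; that floor lies within the scatter), so this change between two six-membered heteroaromatic rings is not shown to exceed the scatter, and its true size stays unread. Measured from the 2-bromophenyl group, the picture is firmer, with an at least 5.1-fold higher number from compound 1 to compound 3 (0.71 log units; beyond the scatter), so at this position both heteroaromatic rings shown sit on the side of weaker growth inhibition relative to the 2-bromophenyl group, each by a step beyond the scatter.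

The compounds shown leave open whether the bromine or the carbocyclic ring itself carries that difference, a question that a plain phenyl or a 2-chlorophenyl group on the same nitrogen would address. They also leave open how a pyridin-2-yl group would read against the pyridin-3-yl and pyrimidin-2-yl rings, and whether an amine or a carboxylic acid on the ring would shift growth inhibition in either direction.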